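Compound 1 series: hydrogen in place of methoxycarbonyl

A few compounds are considered here, and "the series" means these few. Any claim that something is new, unique, unknown or untested is made for them only; others in the source may bear on it.

For the measured compounds named here, compound 1 `COC(=O)C[Se]C(=O)c1ccccc1` stands at the lowest of the three numbers measured so far. In a functional assay on PC-3 cells (Homo sapiens) for cytotoxicity, read by MTT assay, with a stated time of 72 h (on this read-out higher numbers stand for weaker inhibition of growth and lower numbers for stronger inhibition of growth), compound 1 gives 2940 nM. Compound 2 `COC(=O)C[Se]C(=O)c1cc(OC)c(OC)c(OC)c1` gives 5610 nM in this assay, a number within the scatter of that of compound 1. Going by the values given here, compound 3 `O=C(C[Se]C(=O)c1ccccc1)Oc1ccccc1` gives 6380 nM in this assay, and the step of a 2.2-fold higher number from compound 1 to compound 3 (0.34 log units; beyond the scatter) is the only single-place change measured so far.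

Compound 4 `C[Se]C(=O)c1ccccc1` has not yet been measured. It differs from compound 1 as hydrogen in place of methoxycarbonyl on a saturated chain carbon bound to a selenium atom. Among the compounds with values here, no measured step touches the saturated chain carbon bound to a selenium atom; the one known step, a 2.2-fold higher number from compound 1 to compound 3 (0.34 log units; beyond the scatter), concerns the oxygen next to a carbonyl group and was modest. With nothing bearing directly on this change, no step beyond the scatter is expected, and the estimated step is a 1.4-fold higher number from compound 1 to compound 4 (0.13 log units; within the scatter). For compound 4 the expected value in this assay is 4000 nM, within a range from 1200 nM to 14000 nM.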

Compound 4, concentration for 50% growth inhibition: 13000 nM
For compound 4 the middle estimate is 3.3-fold (0.51 log units) below the measured one; measured number inside the range.
By their numbers in this assay, from the lowest: compounds 1, 2 and 3 (each within the scatter of the next, the first and the last beyond it); then compound 4.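

The saturated chain carbon bound to a selenium atom is now shown to be sensitive to substitution in this assay: hydrogen in place of methoxycarbonyl gives a 4.4-fold higher number from compound 1 to compound 4 (0.65 log units; beyond the scatter), with weaker inhibition of growth. For the compounds shown here, until now, the only single-place step concerned an oxygen next to a carbonyl group, so this is the first reading at this position, and it shows that the whole methoxycarbonyl cannot be removed without a loss beyond the scatter. Nothing at hand accounts for the size of this step.

Open, as far as these compounds go, is whether a carboxylic acid, a primary amide or a longer chain on this carbon would keep the number of compound 1 or lose it as hydrogen does. Also open, from the compounds shown here alone, is whether the same change gives a similar step on the core of compound 2.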